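The source may hold more compounds than are shown below. What is called first, only, known or untested is meant among the compounds shown, and "the series" means these compounds.

Working notes on a three-membered set run in an ADME assay on HepG2 cells (Homo sapiens) for cytotoxicity, read by luminescence, CellTiter-Glo and ATP content, with a stated time of 72 h; a lower number here means that less compound is needed, a higher number that more compound is needed for the effect. Compound 1 `COc1ccc(F)cc1CNCCCNc1ccnc2cc(CCc3ccccc3)ccc12` gives 4240 nM and sits at the low end of the numbers in hand. Compound 2 `Cc1cc(C)cc(Cc2ccc3c(NCCCNCc4ccco4)ccnc3c2)c1` gives 6270 nM in this assay, a gap to compound 1 that lies within the scatter. Within the data shown here, compound 3 `c1ccc(CCc2ccc3c(NCCCNCc4ccco4)ccnc3c2)cc1` gives 16000 nM in this assay, the only number beyond the scatter from compound 1: there is a 3.8-fold higher number from compound 1 to compound 3 (0.58 log units; beyond the scatter), and from the second compound there is a 2.6-fold higher number from compound 2 to compound 3 (0.41 log units; beyond the scatter). Both steps alter groups on a saturated chain carbon and say nothing directly about the substituent on the shared core.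

Compound 4 `COc1ccc(F)cc1CNCCCNc1ccnc2cc(Oc3ccccc3)ccc12` differs from compound 1 only there: phenoxy in place of phenethyl on an aromatic carbon. Among the measured compounds shown here, no measured pair alters this position, so there is no step to lean on; the set gives only the general scale of its numbers. The expected change is a 1.1-fold higher number from compound 1 to compound 4 (0.03 log units; within the scatter), kept near zero. Compound 4 is thus estimated at 4500 nM in this assay, with a range from 1800 nM to 11000 nM.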

Compound 4, half-maximal effective concentration: 1500 nM
Compound 4: the middle estimate sits 3.0-fold (0.48 log units) above what was measured; the whole stated range lies above it.
By their numbers in this assay, from the lowest: compound 4; then compounds 1 and 2 (each within the scatter of the next); then compound 3.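

Among these compounds, the earlier steps all changed groups on saturated chain carbons; this is the first reading of the substituent on the shared core. In this assay, with the 5-fluoro-2-methoxyphenyl group held fixed, phenoxy in place of phenethyl on an aromatic carbon gives a 2.8-fold lower number from compound 1 to compound 4 (0.45 log units; beyond the scatter), so this place on the core also moves the number beyond the scatter. Phenoxy brings 7 heavy atoms and 1 hydrogen-bond acceptor where phenethyl has 8 heavy atoms and 0 acceptors, and no measurement on hand accounts for the step.

On these data alone, whether phenoxy gives a step of similar size alongside the furan-2-yl group remains open, as this change is seen in one pair only. Also open, as far as these compounds go, is how a benzyloxy group or an amine link in place of the phenoxy oxygen would read here.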